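This account rests on a few compounds, and the source may have more. Where it says the series, first, only, none or still open, it means among the compounds named here.

Working notes on the hydroxamic acid series. Compound 1 `O=C(NO)c1ccc(Cn2nc(-c3ccc(F)cc3)cc2Cc2ccccc2)cc1` is measured in an assay on cells for inhibition of protein deacetylase HDAC6 (Homo sapiens), read by fluorescence, with stated times of 15 min and 60 min (a higher number here means a weaker inhibitor, a lower number a stronger inhibitor), at 326 nM. Within the three numbers at hand this is the second highest. Compound 3 `O=C(NO)c1ccc(Cn2nc(Cc3ccccc3)cc2-c2ccc(F)cc2)cc1` carries the same two groups on the shared core, arranged differently, and gives 420 nM in this assay, a number within the scatter of that of compound 1, so the two are not told apart. Compound 2 `Cc1ccc(-c2cc(C)nn2Cc2ccc(C(=O)NO)cc2)cc1` gives 29 nM in this assay, beyond the scatter below compound 1 and the lowest of the three.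

Compound 4 `CCc1cc(-c2ccc(F)cc2)nn1Cc1ccc(C(=O)NO)cc1` has not been measured. Relative to compound 1 the change is methyl in place of phenyl on a saturated chain carbon bound to an aromatic carbon. Going by the values given here, no measured pair shows this exact step, so its size is not known from the data. The nearest pointer is compound 2, which carries small alkyl groups on the core and sits well below compound 1. A step toward a lower number, beyond the scatter, is therefore expected, though the fluorophenyl group of compound 4 differs from the tolyl group of compound 2, so the full drop is not assumed. Compound 4 is expected to give about 70 nM in this assay, within 25 nM to 200 nM, an expected change of a 4.7-fold lower number from compound 1 to compound 4 (0.67 log units; beyond the scatter).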

Compound 4, half-maximal inhibitory concentration: 35 nM
Compound 4: the middle estimate sits 2.0-fold (0.30 log units) above what was measured; the range from low to high includes it.
By their numbers in this assay, from the lowest: compounds 2 and 4 (each within the scatter of the next); then compounds 1 and 3 (each within the scatter of the next).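

Within this assay, a 9.3-fold lower number from compound 1 to compound 4 (0.97 log units; beyond the scatter) is the first reading of a single change on the shared core, with benzyl giving way to ethyl and everything else held constant. At this position, on a saturated chain carbon bound to an aromatic carbon, the phenyl and its 6 heavy atoms are therefore not required for a low number, and the series gains when methyl takes its place. The earlier compounds shown here could only hint at this, as none of them formed a pair differing in one place. Nothing at hand accounts for the size of the step or says what lies behind it.

As far as these compounds go, only phenyl and methyl are compared at this position, so it remains open how the number would respond to a longer chain such as propyl or butyl, or to an amine or a carboxylic acid at the end of the chain. Also open, from the compounds shown here alone, is whether the same step holds with the groups arranged as in compound 3, where the benzyl and the fluorophenyl stand the other way round on the shared core.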